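The source may report more compounds than this note shows. Statements on the series, on what has been measured and on what is new or still open speak of the compounds shown alone.

Measured so far, in a functional assay on CRL2813 cells (Homo sapiens) for cytotoxicity, read by sulforhodamine B assay, with a stated time of 5 days; on this read-out lower numbers stand for stronger inhibition and higher numbers for weaker inhibition:

compound 1, `O=C(Nc1cccc(C(F)(F)F)c1)N[C@H]1CC[C@H](Oc2cccc(C(F)(F)F)c2)CC1`, gives 1300 nM
compound 2, `CSc1ccc(NC(=O)N[C@H]2CC[C@H](Oc3ccc(F)cc3)CC2)cc1`, gives > 20000 nM
compound 3, `O=C(Nc1cccc(C(F)(F)F)c1)N[C@H]1CC[C@H](Oc2ccc(OC(F)(F)F)cc2)CC1`, gives 690 nM

Compound 1 and compound 3 share a trifluoromethyl-bearing aryl urea and both give measurable numbers in this assay. Compound 2 is different: its result in this assay is not a number but a limit, (the limit of > 20000 nM in this assay, at which 1 of the 3 values shown sits), so the assay only tells that its inhibition is too weak to be measured at the highest concentration tested. Where compound 2 truly stands is therefore unknown; it could sit just past the limit or far beyond it.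

The step to compound 4, `O=C(Nc1ccccc1F)N[C@H]1CC[C@H](Oc2ccc(F)cc2)CC1`, changes the aryl group on the urea: 2-fluorophenyl in place of 4-(methylsulfanyl)phenyl on an amide-type nitrogen. The other half of the molecule stays as in compound 2. For the measured compounds named here, no measured pair here shows the effect of this exchange, so any expectation rests on the limit alone. Since compound 2 starts at the limit, a step to weaker inhibition cannot be seen at all, and a step to stronger inhibition would have to be large to produce a number. The expected step from compound 2 to compound 4 is an at least 1.3-fold lower number from compound 2 to compound 4 (0.12 log units; that floor lies within the scatter), a modest move toward stronger inhibition that may still leave the result at the limit. Compound 4 is estimated at 15000 nM, between 4000 nM and 40000 nM.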

Compound 4, half-maximal inhibitory concentration: 17500 nM
The estimate for compound 4 lay 1.2-fold (0.07 log units) below the measured number; the measured number falls inside the stated range.
By their numbers in this assay, from the lowest: compounds 3 and 1 (each within the scatter of the next); then compound 4. At a limit, above all of these: compound 2.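

With 2-fluorophenyl in place of 4-(methylsulfanyl)phenyl on an amide-type nitrogen, this assay records an at least 1.1-fold lower number from compound 2 to compound 4 (0.05 log units; that floor lies within the scatter). This step is only a floor, and the true distance between the two compounds cannot be read, so it does not establish a real gain in inhibition; compound 2 remains a limit and not a number: the limit of > 20000 nM in this assay, at which 1 of the 4 values shown sits. What is new is a measurable result for this other part of the molecule, with compound 4 at 17500 nM, so changes on the urea aryl group can now be followed from a number. The compounds shown leave open whether the fluorine itself matters, which a plain phenyl at this place would test. They also leave open how an amine, a carboxylic acid or a longer chain on this nitrogen would read.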